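A few compounds are considered here, and "the series" means these few. Any claim that something is new, unique, unknown or untested is made for them only; others in the source may bear on it.

Measured so far in an assay on isolated protein for inhibition of proto-oncogene tyrosine-protein kinase receptor Ret (Homo sapiens), read by mobility shift assay, with a stated time of 1 h, tested at 10 uM; a lower number here means less inhibition, a higher number more inhibition at the concentration tested (going by the name of the read-out):

compound 1, `CN(C)CCn1cnnc1-c1cc(Oc2ccc(NC(=O)Nc3ccc(F)c(F)c3)cc2F)ccn1` — 17.6%
compound 2, `CN(C)CCn1cnnc1-c1cc(Oc2ccc(NC(=O)Nc3ccc(F)c(Cl)c3)cc2F)ccn1` — 63.3%
compound 3, `CN(C)CCCn1cnnc1-c1cc(Oc2ccc(NC(=O)Nc3ccc(F)c(F)c3)cc2F)ccn1` — 30.9%

Compound 1 and compound 2 differ only by chloro in place of fluoro on an aromatic carbon; the step of a number 45.7 percentage points higher from compound 1 to compound 2 (beyond the scatter) is the largest movement within the three. Compound 3 carries a different chain on the shared core: the difference from compound 1 is (dimethylamino)methyl in place of dimethylamino on a saturated chain carbon, two bonds along the chain from an aromatic nitrogen, and the step of a number 13.3 percentage points higher from compound 1 to compound 3 (beyond the scatter) is beyond the scatter but considerably smaller. In this assay compound 3 stands second of the three numbers, nearer to compound 1 than to compound 2.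

Compound 4, `CN(C)CCCn1cnnc1-c1cc(Oc2ccc(NC(=O)Nc3ccc(F)c(Cl)c3)cc2F)ccn1`, has not yet been measured. It differs from compound 3 by chloro in place of fluoro on an aromatic carbon, the same change as from compound 1 to compound 2, made at the same place word for word. The expectation for compound 4 therefore rests on carrying that change onto the chain of compound 3: the step of a number 41.1 percentage points higher from compound 3 to compound 4 (beyond the scatter) is expected, because the earlier step of a number 45.7 percentage points higher from compound 1 to compound 2 (beyond the scatter) was large and the chain change in compound 3 moved the number only modestly. Compound 4 is estimated at 72%, likely between 52% and 90%.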

Compound 4, a percentage reported as inhibition, at one concentration (the size of the read-out at that concentration, not a potency): 45.5%
Beside the measured number, compound 4's estimate is 26.5 percentage points above it; measured number below the stated range.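

In this assay the change of fluoro to chloro keeps its direction on the chain ending in (dimethylamino)methyl, with a number 14.6 percentage points higher from compound 3 to compound 4 (beyond the scatter), but it does not keep its size: the same change on two cores in this assay, a number 45.7 percentage points higher (beyond the scatter) from compound 1 to compound 2 and a number 14.6 percentage points higher (beyond the scatter) from compound 3 to compound 4, 31.1 percentage points apart, beyond the scatter of two such steps

The chain change does not keep even its direction once the 3-chloro-4-fluorophenyl group is present, with a number 17.8 percentage points lower from compound 2 to compound 4 (beyond the scatter): the same change on two cores in this assay, a number 13.3 percentage points higher (beyond the scatter) from compound 1 to compound 3 and a number 17.8 percentage points lower (beyond the scatter) from compound 2 to compound 4, 31.1 percentage points apart, beyond the scatter of two such steps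

The two changes therefore do not add independently across these four compounds, so a step taken from one core cannot be carried onto another at face value, though a single pair of cores shows neither why the steps differ nor how the chloro step behaves on any other chain.

Left open is how a longer chain, or diethylamino in place of dimethylamino, would behave with each of the two aryl groups. Also open, as far as these compounds go, is whether bromo in place of chloro would follow the same course, and how these single-concentration readings relate to potency.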